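Swapping a benzyl for a phenoxy on the shared core

The source may report more compounds than this note shows. Statements on the series, on what has been measured and on what is new or still open speak of the compounds shown alone.

Among the compounds with values here, compound 2 `Cc1ccccc1Cc1nc2cc(O[C@H]3CC[C@@H](C(=O)O)CC3)ccc2n1C` is the weaker of the two compounds measured so far: in an assay on isolated protein for inhibition of Long-chain-fatty-acid--CoA ligase 1 (Homo sapiens), read by mass spectrometry, with a stated time of 90 min, in the presence of a further agent that is not named here (a higher number here means a weaker inhibitor, a lower number a stronger inhibitor), compound 2 gives 7800 nM, whereas compound 1 `Cc1cccc(Cn2nc3cc(O[C@H]4CC[C@@H](C(=O)O)CC4)ccc3c2C)c1` gives 45 nM, a gap well beyond the scatter of repeated measurements. Compound 3 `Cc1cccc(Oc2nc3cc(O[C@H]4CC[C@@H](C(=O)O)CC4)ccc3n2C)c1` has not yet been measured. It differs from compound 2 in one place: 3-methylphenoxy in place of 2-methylbenzyl on an aromatic carbon between two ring nitrogen atoms of the five-membered ring. Within the data shown here, no measured pair shows the effect of this exchange, so the expectation rests on compound 2 alone. The step from compound 2 to compound 3 is expected to be small, most likely within the scatter or a modest gain in potency, a 1.6-fold lower number from compound 2 to compound 3 (0.19 log units; within the scatter). Compound 3 is therefore estimated to give about 5000 nM in this assay, with a plausible range from 1000 nM to 25000 nM.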

Compound 3, half-maximal inhibitory concentration: 78000 nM
The estimate for compound 3 lay 16-fold (1.19 log units) below the measured number; the measured number lies above the stated range.
By their numbers in this assay, from the lowest: compound 1; then compound 2; then compound 3.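

In this assay the exchange on this aromatic carbon between two ring nitrogen atoms gives a 10-fold higher number from compound 2 to compound 3 (1.00 log units; beyond the scatter) so this position clearly responds to the swap, and the inhibitor becomes weaker. The two groups have the same count of heavy atoms and each holds one six-membered carbon ring, yet 3-methylphenoxy brings an oxygen and one hydrogen-bond acceptor, and its methyl group is named at a different ring position from that in 2-methylbenzyl, so this single step joins more than one change. No available measurement accounts for the drop in potency.

As far as these compounds go, what stays open is which of these changes carries the step: 3-methylbenzyl or 2-methylphenoxy on this carbon would separate them. Also open, from the compounds shown here alone, is how an amine linking the ring to the core would compare with the oxygen of compound 3.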